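Opening the Amine Ring on the Shared Core

A few compounds are considered here, and "the series" means these few. Any claim that something is new, unique, unknown or untested is made for them only; others in the source may bear on it.

In an assay on HeLa cells for inhibition of sphingosine-1-phosphate transporter SPNS2 (Mus musculus), read by LC-MS, tested at 2 uM (on this read-out higher numbers stand for more inhibition at the one concentration tested (going by the name of the read-out) and lower numbers for less inhibition), compound 2 `CCCCCCCCCCc1ccc(-c2noc(C3CCNCC3)n2)cc1` gives 66%, the highest of the three measured numbers: compound 1 `CCCCCCCCCCc1ccc(-c2noc(CC3CCNC3)n2)cc1` gives 44% and compound 3 `CCCCCCCCCCc1ccc(-c2noc(CCCN3CCCC3)n2)cc1` gives 3%. Compound 4 `CCCCCCCCCCc1ccc(-c2noc(CC(O)CNCC)n2)cc1` is not yet measured; against compound 2 its change is 3-(ethylamino)-2-hydroxypropyl in place of piperidin-4-yl on an aromatic carbon. For the measured compounds named here, two measured steps bear on this. Exchanging one ring amine for another moved the result a number 22 percentage points higher from compound 1 to compound 2 (beyond the scatter), while putting 3-(pyrrolidin-1-yl)propyl in place of piperidin-4-yl moved it a number 63 percentage points lower from compound 2 to compound 3 (beyond the scatter); the related step of a number 41 percentage points lower from compound 1 to compound 3 (beyond the scatter) points the same way. Since the entering group likewise has no ring, the step to compound 4 is expected to be a drop, a number 36 percentage points lower from compound 2 to compound 4 (beyond the scatter). Compound 4 is therefore estimated at 30%, within 5% to 58%.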

Compound 4, a percentage reported as inhibition, at one concentration (the size of the read-out at that concentration, not a potency): 5%
For compound 4 the middle estimate is 25 percentage points above the measured one, and the stated range covers the measured number.
By their numbers in this assay, from the lowest: compounds 3 and 4 (each within the scatter of the next); then compound 1; then compound 2.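

In this assay the 3-(ethylamino)-2-hydroxypropyl chain keeps little of what piperidin-4-yl gives, with a number 61 percentage points lower from compound 2 to compound 4 (beyond the scatter) as the step, and it also falls short of compound 1, with a number 39 percentage points lower from compound 1 to compound 4 (beyond the scatter) as the step. Compound 3 keeps a ring at the end of its chain while compound 4 has none, yet a number 2 percentage points higher from compound 3 to compound 4 (within the scatter) is the step between them, so a ring alone does not separate these two. No measurement shown here explains the loss.

Still open, as far as these compounds go, is whether the hydroxyl group matters, which 3-(ethylamino)propyl would test. From the compounds shown here alone, a smaller amine ring, azetidin-3-yl, on the same aromatic carbon also remains open.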